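Rearranging one side group: compound 3 to compound 4

The source may report more compounds than this note shows. Statements on the series, on what has been measured and on what is new or still open speak of the compounds shown alone.

compound 1 `Cc1nc(-c2nc[nH]n2)ccc1-c1cnc2c(n1)N(CC1CCOCC1)C(=O)CN2` gives 100% 
compound 2 `Cc1nc(-c2nc[nH]n2)ccc1-c1cnc2c(n1)N(C(C)C)C(=O)CN2` gives 99% 
compound 3 `CO[C@H]1CC[C@H](N2C(=O)CNc3ncc(-c4ccc(-c5nc[nH]n5)nc4C)nc32)CC1` gives 82% 

These values come from an ADME assay on S9 fraction from liver (Homo sapiens) for metabolic stability, with a stated time of 60 min (on this read-out lower numbers stand for a less stable compound and higher numbers for a more stable compound), and all three compounds share one core. Compound 3 stands lowest of the three, and the gap to each of the others lies beyond the scatter. The step of a number 1 percentage points lower from compound 1 to compound 2 (within the scatter) stays within the scatter, so the two remaining compounds cannot be ranked against each other.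

Compound 4 `Cc1nc(-c2nc[nH]n2)ccc1-c1cnc2c(n1)N(CCC1CCOCC1)C(=O)CN2` has not been measured yet. Compared with compound 3 it carries 2-(oxan-4-yl)ethyl in place of 4-methoxycyclohexyl on an amide-type nitrogen in a ring and so has the same atoms joined differently.

The nearest guide is the step of a number 18 percentage points lower from compound 1 to compound 3 (beyond the scatter) as compound 1 bears (oxan-4-yl)methyl, the measured group closest to the incoming 2-(oxan-4-yl)ethyl. The step of a number 17 percentage points lower from compound 2 to compound 3 (beyond the scatter) is of similar, modest size and points the same way, with 4-methoxycyclohexyl on the lower side both times. Read backwards, these two steps suggest that leaving 4-methoxycyclohexyl raises the number. Among the compounds with values here, no compound with 2-(oxan-4-yl)ethyl has been measured, however, so the full gap may not be recovered.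

A modest rise is therefore expected, estimated as a number 11 percentage points higher from compound 3 to compound 4 (beyond the scatter) in size. Compound 4 is expected to give about 93% (estimated range 80% to 100%).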

Compound 4, percent of the compound remaining: 100%
The estimate for compound 4 lay 7 percentage points below the measured number; low and high end bracket the measured number.
By their numbers in this assay, from the lowest: compound 3; then compounds 2, 1 and 4 (each within the scatter of the next).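

In this assay, 2-(oxan-4-yl)ethyl replaces 4-methoxycyclohexyl on the amide-type nitrogen (a number 18 percentage points higher from compound 3 to compound 4 (beyond the scatter)), and the two groups have the same atoms and the same counts of hydrogen-bond donors and acceptors, so those shared features alone do not set the number at this position. Within the data shown here, the new group also shows no separation from the other two compounds with higher numbers (a number 1 percentage points higher from compound 2 to compound 4 (within the scatter); no change at the digits printed from compound 1 to compound 4 (within the scatter)), which leaves 4-methoxycyclohexyl as the only one of the four groups with a number beyond the scatter from the rest. Nothing measured here explains why this one group stands apart.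

The compounds shown do not separate the possible structural sources of the gap, such as the methoxy group or a ring bound directly to the nitrogen, and plain cyclohexyl or oxan-4-yl placed directly on the amide-type nitrogen would test these. Going by these compounds, it also remains open whether the number holds with a longer chain or with an amine at the end of the chain.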